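The source may report more compounds than this note shows. Statements on the series, on what has been measured and on what is new or still open speak of the compounds shown alone.

Compound 2 `C#Cc1cn([C@@H]2O[C@H](CO)[C@@H](O)[C@H]2O)c2ncnc(N(C)C)c12` is measured in a functional assay on CCRF-CEM cells (Homo sapiens), read by MTT assay, with a stated time of 72 h (a lower number here means a stronger inhibitor, a higher number a weaker inhibitor), and gives 90 nM. Compound 1 `CN(C)c1ncnc2c1c(-c1ccoc1)cn2[C@@H]1O[C@H](CO)[C@@H](O)[C@H]1O` shares its core, and the change furan-3-yl in place of ethynyl on an aromatic carbon brought a 150-fold higher number from compound 2 to compound 1 (2.17 log units; beyond the scatter). Compound 3 `C#Cc1cn([C@@H]2O[C@H](CO)[C@@H](O)[C@H]2O)c2nc(N)nc(OC)c12` carries the same ethynyl group on another core; how its core differs from the core of compound 2 is not broken down here. In this assay compound 3 gives > 100000 nM, which is a limit of the assay rather than a number, the limit described by the limit of > 100000 nM in this assay, at which 1 of the 3 values shown sits.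

Compound 4 `COc1nc(N)nc2c1c(-c1ccoc1)cn2[C@@H]1O[C@H](CO)[C@@H](O)[C@H]1O` has not yet been measured. It differs from compound 3 by furan-3-yl in place of ethynyl on an aromatic carbon, the same change as from compound 2 to compound 1, made on the same place of the core. Within the data shown here, the one measured example of this change weakened compound 1 to 13300 nM. The step that the limit leaves unreadable from compound 3 to compound 4 is expected to run the same way, resting on a 150-fold higher number from compound 2 to compound 1 (2.17 log units; beyond the scatter). Compound 4 is therefore estimated at 500000 nM in this assay, most likely reported again only as a limit.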

Compound 4, half-maximal inhibitory concentration: > 20000 nM
Compound 4: only a limit was reported (the forecaster's own chance of this, stated with the estimate: 90%); the middle value is on the limit's open side.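

Among these compounds, compound 3 and compound 4 are both reported only as limits of the assay, and no step between them can be read. The compounds shown leave open how far furan-3-yl in place of ethynyl on an aromatic carbon moves the number on the core of compound 3, and whether that shift matches the one seen on the core of compound 2.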